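Swapping the thiadiazole arm for a phenyltetrazole

The source may hold more compounds than are shown below. What is called first, only, known or untested is meant among the compounds shown, and "the series" means these compounds.

Three measured compounds share one core and differ only at a single aromatic carbon: compound 1 `Cc1nnc(SCC(=O)N/N=c2/scc(-c3ccccc3)n2-c2ccccc2)s1` carries hydrogen there, compound 2 `Cc1nnc(SCC(=O)N/N=c2/scc(-c3ccc(F)cc3)n2-c2ccccc2)s1` a fluoro group, and compound 3 `Cc1nnc(SCC(=O)N/N=c2/scc(-c3ccc(Cl)cc3)n2-c2ccccc2)s1` a chloro group. In an ADME assay on NIH3T3 cells (Mus musculus) for cytotoxicity, read by MTT assay, with a stated time of 24 h (a higher number here means a weaker inhibitor, a lower number a stronger inhibitor), compound 1 gives 197 ug/mL. Compound 2 gives 383 ug/mL, and compound 3 gives 253 ug/mL. The three steps among them, a 1.9-fold higher number from compound 1 to compound 2 (0.29 log units; within the scatter), a 1.3-fold higher number from compound 1 to compound 3 (0.11 log units; within the scatter) and a 1.5-fold lower number from compound 2 to compound 3 (0.18 log units; within the scatter), all stay within the scatter, so the three numbers are best read as one shared level. Compound 2 sits at one end of that level, with compound 3 closest and compound 1 furthest, but neither gap is meaningful.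

Compound 4 `O=C(CSc1nnnn1-c1ccccc1)N/N=c1/scc(-c2ccc(F)cc2)n1-c1ccccc1` keeps the fluoro group of compound 2 and changes the other end of the molecule: 1-phenyl-1H-tetrazol-5-yl in place of 5-methyl-1,3,4-thiadiazol-2-yl on a sulfur. Among the compounds with values here, none of the measured steps touches this part of the molecule; they all concern the halogen on the aromatic carbon, so they give no guide to the direction or size of this change. With no evidence either way, compound 4 is expected to stay near compound 2, at about 350 ug/mL with a range from 140 ug/mL to 850 ug/mL. The step that estimate implies, a 1.1-fold lower number from compound 2 to compound 4 (0.04 log units; within the scatter), is expected to lie within the scatter.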

Compound 4, half-maximal inhibitory concentration: 207 ug/mL
Compound 4: the middle estimate sits 1.7-fold (0.23 log units) above what was measured, within the range that was stated.
By their numbers in this assay, from the lowest: compounds 1, 4, 3 and 2 (each within the scatter of the next).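

In this assay, the swap on the sulfur gives a 1.9-fold lower number from compound 2 to compound 4 (0.27 log units; within the scatter) and so stays within the scatter. Within the data shown here, this is the first measured change at this end of the molecule, and it is not a small edit: the 1-phenyl-1H-tetrazol-5-yl group has one more nitrogen in its five-membered aromatic ring and also brings a six-membered aromatic ring of carbon only, which the 5-methyl-1,3,4-thiadiazol-2-yl group lacks, yet compound 4 remains level with compound 2 in this read-out. No available evidence bears on this result.

As far as these compounds go, a single pair of aromatic groups cannot show how far this result extends, so it remains open whether a group of a different kind on that sulfur, such as a simple amine, a carboxylic acid or a longer saturated chain, would move the number beyond the scatter. From the compounds shown here alone, it is also open whether the 1-phenyl-1H-tetrazol-5-yl group would behave the same way on the core with hydrogen or chloro on the aromatic carbon, as in compound 1 and compound 3.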